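The source may hold more compounds than are shown below. What is called first, only, known or untested is meant among the compounds shown, and "the series" means these compounds.

Series notes. In a functional assay on PC-3 cells (Homo sapiens) for cytotoxicity, read by MTT assay, with a stated time of 72 h (a higher number here means a weaker inhibitor, a lower number a stronger inhibitor), compound 1 `CNC(=O)c1cc(Oc2ccc(C(=O)/C=C/c3ccc(F)cc3Cl)cc2)ccn1` gives 4760 nM. For the measured compounds named here, this is the only number available for the series, so it cannot yet be ranked as strong or weak against any neighbour. For compound 2 `CNC(=O)c1cc(Oc2ccc(/C=C/C(=O)c3ccc([N+](=O)[O-])cc3)cc2)ccn1` the result is "not determined" (no result reported), and for compound 3 `CNC(=O)c1cc(Oc2ccc(/C=C/C(=O)c3ccc(Cl)cc3)cc2)ccn1` it is "not determined" (no result reported), so neither provides a comparison. Going by the values given here, no measured step between two compounds exists, so the series offers no direct evidence on how substitution of the aromatic ring affects the read-out.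

The next compound to be tested is compound 4 `CNC(=O)c1cc(Oc2ccc(C(=O)/C=C/c3cccc(Cl)c3Cl)cc2)ccn1`, which keeps the shared core of compound 1 and changes one group: 2,3-dichlorophenyl in place of 2-chloro-4-fluorophenyl on a double-bonded chain carbon bound to a double-bonded chain carbon. In words, 2,3-dichlorophenyl stands in place of 2-chloro-4-fluorophenyl on a double-bonded chain carbon bound to a double-bonded chain carbon.

With compound 1 at 4760 nM as the sole anchor, no direction of change in this assay can be supported, and no step beyond the usual scatter is expected. The estimated step of a 1.2-fold lower number from compound 1 to compound 4 (0.08 log units; within the scatter) is accordingly expected to stay within that scatter. Among the compounds with values here, the wide range below reflects the single reference value. For compound 4, the expected half-maximal inhibitory concentration is 4000 nM, with an estimated range of 1500 nM to 12000 nM.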

Compound 4, half-maximal inhibitory concentration: > 50000 nM
Compound 4 was reported as a limit (the forecaster's own chance of this, stated with the estimate: 10%); middle value at least 12-fold (1.09 log units) from the limit.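

In this assay, 2,3-dichlorophenyl in place of 2-chloro-4-fluorophenyl on a double-bonded chain carbon bound to a double-bonded chain carbon gives an at least 10-fold higher number from compound 1 to compound 4 (1.02 log units; beyond the scatter). For the compounds shown here, this is the first readable step, and it shows that the read-out is sensitive to the choice of aryl group at this place, even though the two groups match in heavy-atom count, aromatic ring, hydrogen-bond donors and acceptors, and net charge. The reading for compound 4 is a limit of the assay and not a number, so the step gives only a minimum size for the change: the limit of > 50000 nM in this assay, at which 1 of the 4 values shown sits.

The two groups differ both in the halogens they carry and in where their names place them, and the compounds shown do not separate these two differences, while compound 2 and compound 3 carry no result and cannot be read against either compound. On these data alone, it remains open whether 2-chlorophenyl, or a phenyl ring bearing an amine or a carboxylic acid, would read closer to compound 1 or to compound 4 at this place.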